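A few compounds are considered here, and "the series" means these few. Any claim that something is new, unique, unknown or untested is made for them only; others in the source may bear on it.

Compound 1 `CC(C)c1cccc(-n2cc(COc3cccc(NC(=O)Nc4ccc(Cl)c(C(F)(F)F)c4)c3)nn2)c1`: 3250 nM
Compound 2 `O=C(Nc1cccc(OCc2cn(-c3cccc(Cl)c3)nn2)c1)Nc1ccc(Cl)c(C(F)(F)F)c1`: 2020 nM

In a functional assay on HepG2 cells (Homo sapiens) for inhibition, read by MTT assay, with a stated time of 72 h (a higher number here means a weaker inhibitor, a lower number a stronger inhibitor), compound 2 gives 2020 nM. Among the measured compounds shown here, the only other number, that of compound 1, is separated from it by the step of a 1.6-fold lower number from compound 1 to compound 2 (0.21 log units; within the scatter), which lies within the scatter, so the two compounds stand together rather than apart.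

Compound 3 `O=C(Nc1cccc(OCc2cn(-c3ccccc3I)nn2)c1)Nc1ccc(Cl)c(C(F)(F)F)c1` has not been measured. It differs from compound 2 by 2-iodophenyl in place of 3-chlorophenyl on an aromatic nitrogen. For the measured compounds named here, the single measured step concerns a different exchange at a different place on the shared core, and it was itself within the scatter, so it gives no direct guide to the change from compound 2 to compound 3. With nothing in the data that speaks for a shift in either direction, the expectation is a number close to that of compound 2, with no step beyond the scatter.

Compound 3 is therefore estimated at 2500 nM, within a range from 800 nM to 8000 nM. This estimate means a 1.2-fold higher number from compound 2 to compound 3 (0.09 log units; within the scatter), a step expected to stay within the scatter.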

Compound 3, half-maximal inhibitory concentration: 2870 nM
For compound 3 the middle estimate is 1.1-fold (0.06 log units) below the measured one; measured number inside the range.
By their numbers in this assay, from the lowest: compounds 2, 3 and 1 (each within the scatter of the next).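

In this assay, the two exchanges on the aromatic nitrogen that bring in 2-iodophenyl give a 1.4-fold higher number from compound 2 to compound 3 (0.15 log units; within the scatter) and a 1.1-fold lower number from compound 1 to compound 3 (0.05 log units; within the scatter), so 3-chlorophenyl, 3-isopropylphenyl and 2-iodophenyl now all stand together at this position. The earlier compounds shown here showed this only for two groups with the same numbered place on the phenyl ring, whereas compound 3 adds a group that differs from those in both the halogen and its numbered place, and still no step here leaves the scatter. Because both features change together in the step to compound 3, the data cannot separate them, and nothing measured here offers an explanation for the result.

The compounds shown leave open how 2-chlorophenyl or 3-iodophenyl would stand, and those two groups would separate the identity of the halogen from its place on the ring. They also leave open whether a phenyl ring bearing an amine or a carboxylic acid, or a longer alkyl chain on this nitrogen in place of the phenyl ring, would give a step beyond the scatter.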